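The compounds below may be only part of what the source reports. "The series", "measured", "known", "first", "only" and "open" are said of these compounds alone.

Measured compounds:
- Compound 1 `CCN(CC)c1ccc2cc(C(=O)c3ccc(N4CCN(C(=O)COc5ccc(Cl)cc5Cl)CC4)cc3)oc2c1`; in a functional assay on SGC-7901 cells (Homo sapiens) for cytotoxicity, read by MTT assay, with a stated time of 48 h (on this read-out lower numbers stand for stronger inhibition and higher numbers for weaker inhibition), compound 1 gives 6170 nM.
- Compound 2 `CCOC(=O)N1CCN(c2ccc(C(=O)c3cc4ccc(N(CC)CC)cc4o3)cc2)CC1`; in this assay compound 2 reaches only a limit of the measurement, > 40000 nM.
- Compound 3 `CCN(CC)c1ccc2cc(C(=O)c3ccc(N4CCN(S(=O)(=O)c5ccc(Br)c(F)c5)CC4)cc3)oc2c1`; in this assay compound 3 likewise reaches only a limit, > 40000 nM.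

All three share one core, and they differ only in the group carried by the amine nitrogen of the six-membered ring with two nitrogens. Among the compounds with values here, compound 1 is the only one with a real number; the other two sit at the limit of > 40000 nM in this assay, at which 2 of the 3 values shown sit, so compound 1 stands as the sole fixed point.

Compound 4 `CCN(CC)c1ccc2cc(C(=O)c3ccc(N4CCN(S(=O)(=O)c5ccc(C)cc5)CC4)cc3)oc2c1` is the untested member. It differs from compound 1 by (4-methylphenyl)sulfonyl in place of ((2,4-dichlorophenoxy)methyl)carbonyl on an amine nitrogen in a ring. Within the data shown here, two measured steps bear on this. Replacing the same group with a small carbamate gave an at least 6.4-fold higher number from compound 1 to compound 2 (0.81 log units; beyond the scatter), and replacing it with a halogenated arylsulfonyl gave an at least 6.4-fold higher number from compound 1 to compound 3 (0.81 log units; beyond the scatter). The comparison a step that the two limits leave unreadable from compound 2 to compound 3 cannot be read. Compound 4 carries an arylsulfonyl of the kind seen in compound 3, so the expected direction is upward, a weakening by at least a modest step, with a fair chance that only a limit is reported. Compound 4 is therefore expected at 35000 nM, within 10000 nM to 120000 nM, meaning an expected step of a 5.7-fold higher number from compound 1 to compound 4 (0.75 log units; beyond the scatter).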

Compound 4, half-maximal inhibitory concentration: > 40000 nM
Compound 4 gave a limit, no number; the forecaster's own chance of this, stated with the estimate: 60%; at least 1.1-fold (0.05 log units) between middle value and limit.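

In this assay, putting (4-methylphenyl)sulfonyl in place of ((2,4-dichlorophenoxy)methyl)carbonyl on the amine nitrogen in the ring gives an at least 6.4-fold higher number from compound 1 to compound 4 (0.81 log units; beyond the scatter). Compound 3 had left open whether the loss belonged to its bromine and fluorine, but compound 4 carries neither halogen and its arylsulfonyl group still ends at a limit of the assay, so these two halogens are not required for the loss. The steps among compounds 2, 3 and 4 cannot be read, so these three cannot be placed in any order, and compound 1 remains the only fixed point: the limit of > 40000 nM in this assay, at which 3 of the 4 values shown sit.

On these data alone, what stays open is which part of the group on compound 1 goes with its measurable value: the carbonyl, the phenoxymethyl portion or the two chlorines. A (phenoxymethyl)carbonyl group without chlorine or a plain benzoyl group on the same nitrogen would begin to separate these parts, and a small methylsulfonyl group would show whether the aromatic ring of the sulfonyl series matters at all.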